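The compounds below may be only part of what the source reports. "The series", "measured", "known", "first", "only" and "open" are said of these compounds alone.

In a functional assay on HeLa cells (Homo sapiens) for cytotoxicity, read by MTT assay, with a stated time of 72 h (on this read-out lower numbers stand for stronger inhibition and higher numbers for weaker inhibition), compound 3 `Cc1ccc2oc(CSc3nnc(N)s3)cc(=O)c2c1` gives only a limit of > 25000 nM, not a number. Compound 1 `Cc1nnc(SCc2cc(=O)c3cc(Cl)ccc3o2)o1` likewise gives only a limit of > 25000 nM. Compound 2 `Cc1nnc(SCc2cc(=O)c3ccccc3o2)o1` also gives only a limit of > 25000 nM. For the measured compounds named here, the single measured step, a step that the two limits leave unreadable from compound 1 to compound 2, cannot be read, because both of its ends rest at the limit of > 25000 nM in this assay, at which 3 of the 3 values shown sit. Compound 4 `Cc1ccc2oc(CSc3nnc(C)o3)cc(=O)c2c1` carries 5-methyl-1,3,4-oxadiazol-2-yl in place of 5-amino-1,3,4-thiadiazol-2-yl on a sulfur. Going by the values given here, no measured step bears on this exchange, and since every value shown is a limit, nothing beyond the scatter can be foreseen in this assay in either direction. Compound 4 is therefore expected to give 50000 nM, with a range from 25000 nM to 200000 nM, most likely again as a limit. The expected step is a step that the limit leaves unreadable from compound 3 to compound 4.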

Compound 4, half-maximal inhibitory concentration: > 25000 nM
Compound 4 was reported as a limit; the forecaster's own chance of this, stated with the estimate: 90%; the middle value is on the limit's open side.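

No step from compound 1, compound 2 or compound 3 to compound 4 can be read, because all four compounds rest at the same limit: the limit of > 25000 nM in this assay, at which 4 of the 4 values shown sit.

The compounds shown leave open which change, if any, would give a readable value in this assay.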